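The source may hold more compounds than are shown below. What is called first, only, known or untested is meant among the compounds shown, and "the series" means these compounds.

Measured in a functional assay on MCF7 cells (Homo sapiens) for antiproliferative activity, read by MTT assay, with a stated time of 72 h; a higher number here means a weaker inhibitor, a lower number a stronger inhibitor:
Compound 1 `CC1=CC[C@H]2[C@H](CC[C@]2(C)O)C(C)(C)[C@@H]1CC[C@H]1[C@]2(C)CC[C@H](OC(=O)c3ccc(C(F)(F)F)cc3)C(C)(C)O[C@H]2CC[C@@]1(C)O`: 23400 nM
Compound 2 `COc1ccc(C(=O)O[C@H]2CC[C@]3(C)[C@H](CC[C@@](C)(O)[C@H]3CC[C@@H]3C(C)=CC[C@H]4[C@H](CC[C@]4(C)O)C3(C)C)OC2(C)C)cc1`: 41700 nM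
Compound 3 `CC1=CC[C@H]2[C@H](CC[C@]2(C)O)C(C)(C)[C@@H]1CC[C@H]1[C@]2(C)CC[C@H](OC(=O)c3cccc(C(F)(F)F)c3)C(C)(C)O[C@H]2CC[C@@]1(C)O`: 37900 nM

Compound 3 stands within the scatter of both other compounds: a 1.6-fold higher number from compound 1 to compound 3 (0.21 log units; within the scatter), and a 1.1-fold lower number from compound 2 to compound 3 (0.04 log units; within the scatter). Compound 4 `CC1=CC[C@H]2[C@H](CC[C@]2(C)O)C(C)(C)[C@@H]1CC[C@H]1[C@]2(C)CC[C@H](OC(=O)c3ccco3)C(C)(C)O[C@H]2CC[C@@]1(C)O` carries furan-2-yl in place of 3-(trifluoromethyl)phenyl on a carbonyl carbon. Going by the values given here, no measured compound carries furan-2-yl, so no step tests this exchange directly. The nearest evidence is the other changes to this aromatic group, such as a 1.8-fold higher number from compound 1 to compound 2 (0.25 log units; within the scatter), and these also stayed within the scatter. On that limited basis, no step beyond the scatter is expected in this assay. The expected step is a 1.3-fold lower number from compound 3 to compound 4 (0.10 log units; within the scatter). The estimate for compound 4 is 30000 nM, with an expected range of 13000 nM to 65000 nM.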

Compound 4, half-maximal inhibitory concentration: 25700 nM
Estimate against measurement, compound 4: 1.2-fold (0.07 log units) above, within the range that was stated.
By their numbers in this assay, from the lowest: compounds 1, 4, 3 and 2 (each within the scatter of the next).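

In this assay a five-membered aromatic ring with one hetero atom on this carbonyl carbon reads like the six-membered aromatic rings: the exchange gives a 1.5-fold lower number from compound 3 to compound 4 (0.17 log units; within the scatter) and a 1.6-fold lower number from compound 2 to compound 4 (0.21 log units; within the scatter) and a 1.1-fold higher number from compound 1 to compound 4 (0.04 log units; within the scatter) and so stays within the scatter of all three. Replacing the whole substituted phenyl group with furan-2-yl therefore does not separate compound 4 from the earlier esters in this assay.

Going by these compounds, whether a saturated alkyl chain or an amine-bearing aromatic group on this carbonyl carbon would break from this narrow spread remains open. Nothing available here explains why these groups read alike.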